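This account rests on a few compounds, and the source may have more. Where it says the series, first, only, none or still open, it means among the compounds named here.

For the measured compounds named here, in a functional assay on CCRF-CEM cells (Homo sapiens), read by MTT assay, with a stated time of 3 days (a higher number here means a weaker inhibitor, a lower number a stronger inhibitor), compound 1 `CN(C)c1ncnc2[nH]cc(Sc3cccs3)c12` gives 14600 nM and compound 2 `c1coc(-c2ncnc3[nH]cc(Sc4cccs4)c23)c1` gives 7730 nM, so compound 2 stands within the scatter of the only other measured value. Compound 3 `Cc1ncnc2[nH]cc(Sc3cccs3)c12` changes the same aromatic carbon, with methyl in place of furan-2-yl on an aromatic carbon. Going by the values given here, the one measured step at that carbon, a 1.9-fold lower number from compound 1 to compound 2 (0.28 log units; within the scatter), swapped dimethylamino for furan-2-yl and is the only guide, so no change beyond the scatter is expected. The estimated step is a 1.3-fold higher number from compound 2 to compound 3 (0.11 log units; within the scatter). For compound 3 the expected value is 10000 nM, within an estimated range from 4000 nM to 25000 nM.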

Compound 3, half-maximal inhibitory concentration: > 50000 nM
Compound 3: no number, only a limit; the forecaster's own chance of this, stated with the estimate: 10%; middle value at least 5.0-fold (0.69 log units) from the limit.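

Methyl in place of furan-2-yl gives an at least 6.4-fold higher number from compound 2 to compound 3 (0.81 log units; beyond the scatter), and methyl in place of dimethylamino gives an at least 3.4-fold higher number from compound 1 to compound 3 (0.53 log units; beyond the scatter). In this assay the group on this aromatic carbon can therefore move the number beyond the scatter, which the step between compound 1 and compound 2 did not show. Compound 3 has only a limit and not a number: the limit of > 50000 nM in this assay, at which 1 of the 3 values shown sits.

On these data alone, how far compound 3 truly lies from the other two stays open. So does whether a primary amine, an ethyl chain or a phenyl ring on this carbon would behave like methyl or like furan-2-yl.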